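Swapping the triazole aryl group for an amide-bearing chain

The source may report more compounds than this note shows. Statements on the series, on what has been measured and on what is new or still open speak of the compounds shown alone.

Compound 3 `CCOC(=O)C1=Cc2ccccc2OC1(OCc1cn(-c2ccc(F)c([N+](=O)[O-])c2)nn1)C(F)(F)F` has the second highest number among the three measured compounds in a functional assay on DU-145 cells (Homo sapiens) for inhibition, read by MTT assay, with a stated time of 24 h (on this read-out lower numbers stand for stronger inhibition and higher numbers for weaker inhibition), giving 13200 nM. Its nearest neighbour is compound 1 `CCOC(=O)C1=Cc2ccccc2OC1(OCc1cn(-c2ccc(F)cc2)nn1)C(F)(F)F`, which gives 8900 nM; the step between them is a 1.5-fold higher number from compound 1 to compound 3 (0.17 log units; within the scatter). Compound 2 `CCOC(=O)C1=Cc2ccccc2OC1(OCc1cn(CC(=O)Nc2ccc(OC)cc2)nn1)C(F)(F)F` gives 32700 nM, and the step of a 2.5-fold lower number from compound 2 to compound 3 (0.39 log units; beyond the scatter) separates it from compound 3.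

Compound 4 `CCOC(=O)C1=Cc2ccccc2OC1(OCc1cn(CC(=O)Nc2ccccc2F)nn1)C(F)(F)F` has not yet been measured. It differs from compound 3 in one place: ((2-fluorophenyl)carbamoyl)methyl in place of 4-fluoro-3-nitrophenyl on an aromatic nitrogen.

For the measured compounds named here, two measured steps bear on this change, each exchanging an aryl group on an aromatic nitrogen for a chain ending in an amide, or the reverse. In one direction, a 3.7-fold higher number from compound 1 to compound 2 (0.57 log units; beyond the scatter). In the other, a 2.5-fold lower number from compound 2 to compound 3 (0.39 log units; beyond the scatter). Both point the same way: the amide-bearing chain carries the higher number. Going by the values given here, the chain in compound 4 ends in a 2-fluorophenyl group rather than a 4-methoxyphenyl group, and no measured pair separates these two endings, so that part of the change is unknown. Compound 4 is therefore expected to give a higher number than compound 3 by a modest step, a 2.7-fold higher number from compound 3 to compound 4 (0.42 log units; beyond the scatter). The estimate for compound 4 in this assay is 35000 nM, with a range from 15000 nM to 80000 nM.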

Compound 4, half-maximal inhibitory concentration: 33900 nM
Estimate against measurement, compound 4: 1.0-fold (0.01 log units) above, and the stated range covers the measured number.
By their numbers in this assay, from the lowest: compounds 1 and 3 (each within the scatter of the next); then compounds 2 and 4 (each within the scatter of the next).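

Within this assay, the two chains ending in an amide can now be compared directly, and the change at their far end gives (a 1.0-fold higher number from compound 2 to compound 4 (0.02 log units; within the scatter)), so 2-fluorophenyl in place of 4-methoxyphenyl on the amide-type nitrogen leaves the two compounds within the scatter of each other. Exchanging an aryl group on the aromatic nitrogen for such a chain now has a second chain behind it, with modest steps beyond the scatter of (a 2.6-fold higher number from compound 3 to compound 4 (0.41 log units; beyond the scatter)) and (a 3.8-fold higher number from compound 1 to compound 4 (0.58 log units; beyond the scatter)), and among these four compounds both chain-bearing compounds carry higher numbers than both aryl-bearing ones, with none going against this. No measurement at hand gives a reason for this gap between the aryl groups and the amide-ending chains.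

These four compounds do not show whether the higher numbers follow the amide itself or the methylene-linked chain as a whole, since nothing here places a simple benzyl group or a longer chain on that nitrogen. From the compounds shown here alone, how a chain ending in a carboxylic acid or an amine would read at this position also stays open, as does whether any other ending on the amide-type nitrogen would separate from 2-fluorophenyl and 4-methoxyphenyl.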